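Moving the Chlorine on the Phenyl of the Triazole

The source may hold more compounds than are shown below. What is called first, only, known or untested is meant among the compounds shown, and "the series" means these compounds.

In a functional assay on SGC-7901 cells (Homo sapiens) for antiproliferative activity, read by MTT assay, with a stated time of 24 h (a lower number here means a stronger inhibitor, a higher number a weaker inhibitor), compound 1 `O=c1[nH]cc(S(=O)(=O)Nc2ccc(-c3cn(-c4ccccc4)nn3)cc2)c(=O)[nH]1` gives 18800 nM. In this assay compound 2 `Cc1ccc(-n2cc(-c3ccc(NS(=O)(=O)c4c[nH]c(=O)[nH]c4=O)cc3)nn2)cc1` gives 8350 nM. In this assay compound 3 `O=c1[nH]cc(S(=O)(=O)Nc2ccc(-c3cn(-c4ccccc4Cl)nn3)cc2)c(=O)[nH]1` gives 2680 nM.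

Compound 3 stands lowest of the three numbers; its nearest neighbour is compound 2 and the furthest compound 1, both steps beyond the scatter. Compound 4 `O=c1[nH]cc(S(=O)(=O)Nc2ccc(-c3cn(-c4ccc(Cl)cc4)nn3)cc2)c(=O)[nH]1` differs from compound 3 in one place: 4-chlorophenyl in place of 2-chlorophenyl on an aromatic nitrogen.

Going by the values given here, no measured pair shows the same chlorine moving from one position of that phenyl to another, so the bearing steps are indirect. The step of a 7.0-fold lower number from compound 1 to compound 3 (0.85 log units; beyond the scatter) shows what the 2-chlorophenyl brings over plain phenyl; the step of a 2.3-fold lower number from compound 1 to compound 2 (0.35 log units; beyond the scatter) shows what a 4-methylphenyl brings, and the step of a 3.1-fold lower number from compound 2 to compound 3 (0.49 log units; beyond the scatter) shows how far the 2-chlorophenyl outruns it. A group placed as in compound 2 gave a smaller gain than the 2-chlorophenyl of compound 3, so compound 4 is expected to sit between compound 1 and compound 3, giving an estimated step of a 1.9-fold higher number from compound 3 to compound 4 (0.27 log units; within the scatter) in this assay. Compound 4 is therefore estimated at 5000 nM, with a range from 2000 nM to 14000 nM.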

Compound 4, half-maximal inhibitory concentration: 1830 nM
Compound 4: the middle estimate sits 2.7-fold (0.44 log units) above what was measured, and the stated range ends above it.
By their numbers in this assay, from the lowest: compounds 4 and 3 (each within the scatter of the next); then compound 2; then compound 1.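

In this assay, going by these compounds alone, the change to 4-chlorophenyl in place of 2-chlorophenyl on the aromatic nitrogen gives a 1.5-fold lower number from compound 3 to compound 4 (0.17 log units; within the scatter) and is the first direct reading of where the chlorine sits on that phenyl; the two placements cannot be told apart in this assay. The gain over plain phenyl therefore holds for the 4-chlorophenyl as well, with a 10-fold lower number from compound 1 to compound 4 (1.01 log units; beyond the scatter) as the only step among these compounds printed as large, and the comparison with the 4-methylphenyl group gives a 4.6-fold lower number from compound 2 to compound 4 (0.66 log units; beyond the scatter) as a step beyond the scatter. Among the four compounds, then, the numbers at this position separate by which group the phenyl carries, plain hydrogen, methyl or chloro, and not by which of the two shown places holds the chlorine.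

The compounds shown leave open whether a fluoro, a methoxy or an amine on the same phenyl would read like the chloro, and whether a second chlorine would add to what one chlorine gives. Nothing given here explains why the two chlorophenyl compounds read as they do.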